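Tetrazolyl to triazolyl swap at the para position

A few compounds are considered here, and "the series" means these few. Any claim that something is new, unique, unknown or untested is made for them only; others in the source may bear on it.

Compound 2 `CCC(C)(C)Cc1c[nH]c(CCc2ccc(-n3ncnn3)cc2)n1` gives the highest number of the three measured in an in vitro assay on CHO cells for displacement of a labelled ligand from Bombesin receptor subtype-3 (Homo sapiens), read by scintillation counting, with a stated time of 2 h (on this read-out lower numbers stand for stronger inhibition and higher numbers for weaker inhibition), at 205 nM. Compound 1 `CCC(C)(C)Cc1c[nH]c(CCc2ccc(-c3cccc(C)n3)cc2)n1` gives 6.3 nM and compound 3 `CCC(C)(C)Cc1c[nH]c(CCc2ccc(-c3ccccc3C(=O)O)cc2)n1` gives 11 nM; the steps of a 33-fold higher number from compound 1 to compound 2 (1.51 log units; beyond the scatter) and a 19-fold lower number from compound 2 to compound 3 (1.27 log units; beyond the scatter) are both large, whereas a 1.7-fold higher number from compound 1 to compound 3 (0.24 log units; within the scatter) is not. Compound 4 `CCC(C)(C)Cc1c[nH]c(CCc2ccc(-n3cncn3)cc2)n1` differs from compound 2 by 1H-1,2,4-triazol-1-yl in place of 2H-tetrazol-2-yl on an aromatic carbon. For the measured compounds named here, no measured step exchanges one five-membered nitrogen-linked ring for another; the two large steps involving compound 2 each replace the 2H-tetrazol-2-yl with a six-membered ring, so they do not bear directly on this change. The step from compound 2 to compound 4 in this assay is therefore expected to be a 1.4-fold lower number from compound 2 to compound 4 (0.14 log units; within the scatter), not beyond the scatter. Compound 4 is estimated at 150 nM in this assay, within 45 nM to 500 nM.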

Compound 4, half-maximal inhibitory concentration: 340 nM
Beside the measured number, compound 4's estimate is 2.3-fold (0.36 log units) below it, and the stated range covers the measured number.
By their numbers in this assay, from the lowest: compounds 1 and 3 (each within the scatter of the next); then compounds 2 and 4 (each within the scatter of the next).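

In this assay the exchange of 2H-tetrazol-2-yl for 1H-1,2,4-triazol-1-yl, with one ring nitrogen fewer, gives a 1.7-fold higher number from compound 2 to compound 4 (0.22 log units; within the scatter) and so does not separate the two five-membered rings. Both a 31-fold higher number from compound 3 to compound 4 (1.49 log units; beyond the scatter) and a 54-fold higher number from compound 1 to compound 4 (1.73 log units; beyond the scatter) are large, so among these compounds the large steps at this position come with leaving the six-membered ring groups, whichever five-membered ring enters. No measurement at hand accounts for this gap.

Still open, as far as these compounds go, is whether the gap follows ring size or the nitrogen link, which an unsubstituted phenyl or a carbon-linked oxazole at this position would test.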